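Two ring stereocentres inverted in a peroxide acid

This account rests on a few compounds, and the source may have more. Where it says the series, first, only, none or still open, it means among the compounds named here.

Compounds with measured values:
compound 1 `C=C1CCCC(C)(C)C1CC[C@]1(C)CC[C@@H]([C@@H](C)C(=O)O)OO1`: > 10000 nM
compound 2 `C=C1CCCC(C)(C)C1CC[C@]1(C)CC[C@H]([C@@H](C)C(=O)OC)OO1`: 4400 nM
compound 3 `C=C1CCC[C@H]2[C@](C)(CC[C@]3(C)CC[C@@H]([C@@H](C)C(=O)O)OO3)[C@@H](C)CC[C@]12C`: 970 nM

The account follows compound 1 to compound 4 `C=C1CCCC(C)(C)C1CC[C@@]1(C)CC[C@H]([C@@H](C)C(=O)O)OO1` in a functional assay on SK-OV-3 cells (Homo sapiens) for inhibition; a higher number here means a weaker inhibitor of growth, a lower number a stronger inhibitor of growth. Compound 1 gives only a limit in this assay, > 10000 nM, which is not a number; it sits at the limit of > 10000 nM in this assay, at which 1 of the 3 values shown sits, and no measured value is known for it. Compound 2 gives 4400 nM in this assay. Compound 3 gives 970 nM in this assay. Going by the values given here, no single-change step between any two of the measured compounds exists, so no measured step can be read off.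

Compound 4 differs from compound 1 as follows: the two compounds have the same atoms and bonds; at least one stereo element is drawn with a configuration in one of them and without one in the other: 2 of 4 stereo elements differ; a stereocentre at a saturated ring carbon is drawn R in compound 1 and S in compound 4; a stereocentre at a saturated ring carbon is drawn S in compound 1 and R in compound 4. The two compounds therefore share all atoms and bonds and differ only in the drawn configuration at two ring carbons.

Among the compounds with values here, nothing among the measured compounds shows how such an inversion moves growth inhibition, and compound 1 itself has no number to start from. A step beyond the scatter in either direction is possible, yet with no evidence for one, the step from compound 1 to compound 4 is expected to be an at least 1.1-fold lower number from compound 1 to compound 4 (0.04 log units; that floor lies within the scatter). Compound 4 is estimated at 9000 nM in this assay, within 2500 nM to 30000 nM.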

Compound 4, concentration for 50% growth inhibition: 9240 nM
Compound 4: middle estimate off by 1.0-fold (0.01 log units), on the low side; measured number inside the range.
By their numbers in this assay, from the lowest: compound 3; then compound 2; then compound 4. At a limit, above all of these: compound 1.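

Compound 4 carries the same atoms and bonds as compound 1 and differs only at two saturated ring carbons, and in this assay compound 4 gives a true number, 9240 nM. Compound 1 gives only a limit of the assay, > 10000 nM, which is not a number. The change at these two ring carbons can therefore be stated only as a floor, an at least 1.0-fold lower number from compound 1 to compound 4 (0.03 log units; that floor lies within the scatter), so a larger step is not ruled out, and none beyond the scatter is shown: the limit of > 10000 nM in this assay, at which 1 of the 4 values shown sits.

Going by these compounds, whether one ring carbon alone or only the two together move growth inhibition stays open, and the pair must also be read with care: the fact that one of compounds 1 and 4 is drawn with a defined configuration and the other without, at the place where they differ Also open is how compound 4 would respond if a primary amide stood in place of its carboxylic acid.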